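A few compounds are considered here, and "the series" means these few. Any claim that something is new, unique, unknown or untested is made for them only; others in the source may bear on it.

Of the compounds shown here, three of a shared core have been measured in a functional assay on PC-3 cells (Homo sapiens) for inhibition, read by sulforhodamine B assay; a higher number here means a weaker inhibitor of growth, a lower number a stronger inhibitor of growth. Compound 1 `O=C(CCC1=CCN(CCCc2ccc(Br)cc2)C1=O)NO` gives 3480 nM. Compound 2 `Cc1cccc(CN2CC=C(CCC(=O)NO)C2=O)c1` gives 4620 nM, and compound 3 `O=C(CCC1=CCN(Cc2ccc(F)cc2)C1=O)NO` gives 5310 nM. Compound 1 carries the lowest of the three numbers, but the gaps to compound 2 and to compound 3 both lie within the usual scatter, so the three cannot be set apart from one another in this assay.

Compound 4 `Cc1ccc(CCCN2CC=C(CCC(=O)NO)C2=O)cc1` has not yet been measured. It differs from compound 1 at one place: methyl in place of bromo on an aromatic carbon. Going by the values given here, no pair of measured compounds shows this same exchange, so nothing in the set gives the size of the step directly. Since the three measured numbers are all so close, the expectation for compound 4 is a step of no more than the scatter in either direction, a 1.0-fold higher number from compound 1 to compound 4 (0.00 log units; within the scatter). Compound 4 is therefore estimated at 3500 nM, with a range from 1700 nM to 7200 nM.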

Compound 4, concentration for 50% growth inhibition: 3480 nM
Beside the measured number, compound 4's estimate is 1.0-fold (0.00 log units) above it; low and high end bracket the measured number.
By their numbers in this assay, from the lowest: compounds 1, 4, 2 and 3 (each within the scatter of the next).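

In this assay, the exchange of bromo for methyl on the aromatic carbon, para to a large group, gives no change at the digits printed from compound 1 to compound 4 (within the scatter). Going by these compounds alone, this is the first direct reading at this position, and it shows that the bromine of the 4-bromophenyl group is not required for the growth inhibition seen with compound 1, since a methyl carbon in its place leaves the two compounds indistinguishable. Nothing available explains why this exchange leaves the reading where it stands.

Within the data shown here, this single step covers only two groups of one heavy atom each, so it does not show whether this position tolerates change in general. An amine, a carboxylic acid or a longer chain at the same place could still give a different number, and the same holds for plain hydrogen there.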